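A few compounds are considered here, and "the series" means these few. Any claim that something is new, unique, unknown or untested is made for them only; others in the source may bear on it.

Among the measured compounds shown here, in an ADME assay on Huh-7 cells (Homo sapiens) for cytotoxicity, with a stated time of 24 h (a higher number here means that more compound is tolerated, a lower number that less compound is tolerated), compound 1 (`COc1ccc(/C=C\c2cc(OC)c(OC)c(OC)c2)cc1NC(=O)CN`) gives 173000 nM as the only true number so far. Compound 2 (`COc1ccc(/C=C\c2cc(OC)c(OC)c(OC)c2)cc1NC(=O)CNC(=O)[C@H](CCCNC(=N)N)NC(=O)[C@H](CCCCN)NC(=O)c1ccccc1`) gives > 100000 nM as a limit of the assay and not a number. Compound 3 (`COc1ccc(/C=C\c2cc(OC)c(OC)c(OC)c2)cc1NC(=O)[C@H](C)N`) departs from compound 1 by a single change methyl in place of hydrogen on a saturated chain carbon bound to an amine nitrogen and a carbonyl carbon and is otherwise the same. That change is methyl in place of hydrogen on a saturated chain carbon bound to an amine nitrogen and a carbonyl carbon. For the measured compounds named here, no measured pair shows this change, so no shift beyond the scatter is expected in either direction in this assay. The expected 1.2-fold lower number from compound 1 to compound 3 (0.06 log units; within the scatter) remains small. For compound 3 the estimate is 150000 nM with an expected range of 70000 nM to 320000 nM in this read-out.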

Compound 3, half-maximal cytotoxic concentration: 123000 nM
Compound 3: middle estimate off by 1.2-fold (0.09 log units), on the high side, and the stated range covers the measured number.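

In this assay, methyl in place of hydrogen on a saturated chain carbon bound to an amine nitrogen and a carbonyl carbon now has a measured step: a 1.4-fold lower number from compound 1 to compound 3 (0.15 log units; within the scatter). This position thus takes the methyl without a shift beyond the scatter, a reading that rests on this single pair. Compound 2 remains a limit of the assay and not a number: the limit of > 100000 nM in this assay, at which 1 of the 3 values shown sits.

Left open is whether a longer chain, such as isopropyl, or a hydroxymethyl on this carbon would also stay within the scatter.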